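The compounds below may be only part of what the source reports. "The series", "measured", "known", "first", "only" and "open" are said of these compounds alone.

Measured in a functional assay on CAL-51 cells (Homo sapiens) for inhibition, read by sulforhodamine B assay, with a stated time of 3 days; on this read-out higher numbers stand for weaker inhibition of growth and lower numbers for stronger inhibition of growth:

- compound 1 `O=C(/C=C/c1ccccc1Cl)c1ccc(OCc2ccccc2)cc1`: 7100 nM
- compound 2 `O=C(/C=C/c1cccc([N+](=O)[O-])c1)c1ccccc1`: 1080 nM
- compound 3 `O=C(/C=C/c1ccc(OCc2ccccc2)cc1)c1ccccc1`: 24700 nM

Compound 1, at 7100 nM, stands in the middle of this small set. Compound 2 has a lower number, 1080 nM, and compound 3 a higher one, 24700 nM. Both gaps from compound 1 lie beyond the usual scatter.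

Compound 4 `O=C(/C=C/c1ccccc1)c1ccc(OCc2ccccc2)cc1` differs from compound 1 in one place: hydrogen in place of chloro on an aromatic carbon. Hydrogen replaces chloro on an aromatic carbon, ortho to a large group, turning 2-chlorophenyl into phenyl.

Among the compounds with values here, no measured pair shows this change alone, so the guide is weak. Compound 2 and compound 3 also lack chloro, yet they fall on opposite sides of compound 1, and each differs from it in more than one place. In this assay, a small move toward a higher number is expected, and it may stay within the scatter. The expected change is a 1.4-fold higher number from compound 1 to compound 4 (0.15 log units; within the scatter). For compound 4, the estimated value is 10000 nM, with an expected range from 3500 nM to 30000 nM.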

Compound 4, concentration for 50% growth inhibition: 28900 nM
Compound 4: the middle estimate sits 2.9-fold (0.46 log units) below what was measured; low and high end bracket the measured number.
By their numbers in this assay, from the lowest: compound 2; then compound 1; then compounds 3 and 4 (each within the scatter of the next).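

Within the data shown here, compounds 1 and 4 form the first pair in this set to differ in one place, so the effect of this change can be read without other differences getting in the way. Replacing chloro with hydrogen, which turns 2-chlorophenyl into phenyl, gives a 4.1-fold higher number from compound 1 to compound 4 (0.61 log units; beyond the scatter) in this assay and so weaker inhibition of growth, a step beyond the scatter. On this core, then, the chloro ortho to a large group goes with stronger inhibition, though no measurement here explains the step.

As far as these compounds go, whether bromo, a methoxy group or an amine at this same place would match chloro, fall short of it or surpass it remains open. This single pair also cannot show whether the same swap would give a similar step on another core.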